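A Methoxy Group Removed: What to Expect for Compound 4

This account rests on a few compounds, and the source may have more. Where it says the series, first, only, none or still open, it means among the compounds named here.

Measured compounds:
- compound 1, `O=C1NC(=O)/C(=C/c2cn(Cc3ccccc3Br)c3ccccc23)N1`: 39500 nM
- compound 2, `O=C1NC(=O)/C(=C/c2cn(Cc3ccccc3)c3ccc(Cl)cc23)N1`: 29700 nM
- compound 3, `COc1ccc(Cn2cc(/C=C3\NC(=O)NC3=O)c3cc(Br)ccc32)cc1`: 25200 nM

These three values come from a functional assay on A549 cells (Homo sapiens) for antiproliferative activity, read by trypan blue exclusion, with a stated time of 24 h; on this read-out lower numbers stand for stronger inhibition and higher numbers for weaker inhibition. Compound 3 carries the lowest number of the three, but its gaps to compound 2 and to compound 1 both lie within the scatter, so no ordering can be read from them. Compound 4, `O=C1NC(=O)/C(=C/c2cn(Cc3ccccc3)c3ccc(Br)cc23)N1`, differs from compound 3 by hydrogen in place of methoxy on an aromatic carbon. Going by the values given here, no measured pair shows this change directly. Compound 2, which also bears a benzyl without a methoxy, gives 29700 nM, a number close to that of compound 3. In this assay the step from compound 3 to compound 4 is therefore expected to be a 1.2-fold higher number from compound 3 to compound 4 (0.08 log units; within the scatter), not beyond the scatter in either direction. Compound 4 is estimated at 30000 nM, within 12000 nM to 75000 nM.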

Compound 4, half-maximal inhibitory concentration: > 40000 nM
Compound 4 gave a limit, no number; the forecaster's own chance of this, stated with the estimate: 10%; at least 1.3-fold (0.12 log units) between middle value and limit.
By their numbers in this assay, from the lowest: compounds 3, 2 and 1 (each within the scatter of the next). At a limit, above all of these: compound 4.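

In this assay compound 4 gives > 40000 nM, which is a limit and not a number. Hydrogen in place of methoxy on this aromatic carbon gives an at least 1.5-fold higher number from compound 3 to compound 4 (0.20 log units; that floor lies within the scatter), and bromo in place of chloro gives an at least 1.3-fold higher number from compound 2 to compound 4 (0.12 log units; that floor lies within the scatter). Neither floor clears the scatter, so these steps establish no firm effect, though neither change brought a lower number. As far as these compounds go, the true value of compound 4 remains open, as does what an amine, a carboxylic acid or a hydroxy group on that same aromatic carbon would give.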